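This account rests on a few compounds, and the source may have more. Where it says the series, first, only, none or still open, it means among the compounds named here.

Values in a functional assay on NCI-H520 cells (Homo sapiens) for cytotoxicity; on this read-out lower numbers stand for stronger inhibition of growth and higher numbers for weaker inhibition of growth:
- compound 1 `CSc1ccc(C2=C(c3ccc(F)c(F)c3)C(=O)N3CCCC3C2)cc1`: 200 nM
- compound 2 `CSc1ccc(C2=C(c3ccc(C)c(C)c3)C(=O)N3CCCC3C2)cc1`: 300 nM
- compound 3 `CSc1ccc(C2=C(c3ccc(C)cc3)C(=O)N3CCCC3C2)cc1`: 900 nM

Compound 3 has the highest number of the three. Compound 4 `CSc1ccc(C2=C(c3ccc(SC)cc3)C(=O)N3CCCC3C2)cc1` has methylsulfanyl in place of methyl on an aromatic carbon, para to a large group (methylsulfanyl in place of methyl on an aromatic carbon).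

The closest measured changes are a 3.0-fold higher number from compound 2 to compound 3 (0.48 log units; beyond the scatter) and a 4.5-fold higher number from compound 1 to compound 3 (0.65 log units; beyond the scatter), both modest, while a 1.5-fold higher number from compound 1 to compound 2 (0.18 log units; within the scatter) stays within the scatter. None of them introduces methylsulfanyl, so the direction is poorly defined, with only a slight lean towards a lower number. The expected change is a 1.5-fold lower number from compound 3 to compound 4 (0.18 log units; within the scatter), so no step beyond the scatter is expected in this assay. The estimated value for compound 4 is 600 nM, with an expected range of 200 nM to 1800 nM.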

Compound 4, concentration for 50% growth inhibition: 15000 nM
The estimate for compound 4 lay 25-fold (1.40 log units) below the measured number; measured number above the stated range.
By their numbers in this assay, from the lowest: compounds 1 and 2 (each within the scatter of the next); then compound 3; then compound 4.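

In this assay, among these compounds, exchanging the methyl group for methylsulfanyl gives a 17-fold higher number from compound 3 to compound 4 (1.22 log units; beyond the scatter), much larger than any step among the earlier compounds. The 4-(methylsulfanyl)phenyl group also falls far behind 3,4-dimethylphenyl and 3,4-difluorophenyl, with a 50-fold higher number from compound 2 to compound 4 (1.70 log units; beyond the scatter) and a 75-fold higher number from compound 1 to compound 4 (1.88 log units; beyond the scatter), so this position does not accept every small group alike. Nothing on hand bears on the reason for this loss.

Open, going by these compounds, is whether the loss belongs to the sulfur or to the longer group, which a methoxy or an ethyl group at this carbon would separate.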